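Moving a Chlorine Around the Pendant Phenyl Ring

The compounds below may be only part of what the source reports. "The series", "measured", "known", "first", "only" and "open" are said of these compounds alone.

Compounds measured so far:
- compound 1, `O=S(=O)(c1cc(F)cc(F)c1)c1cnc2c(F)cccc2c1-c1cccc(Cl)c1`: 0.64 mL/min
- compound 2, `COc1ccc(S(=O)(=O)c2cnc3c(F)cccc3c2-c2cccc(F)c2)cc1`: 3.03 mL/min
- compound 3, `COc1ccc(S(=O)(=O)c2cnc3c(F)cccc3c2-c2ccc(Cl)cc2)cc1`: 1.05 mL/min

In an ADME assay on microsomes from liver (Homo sapiens) for metabolic stability, tested at 2.5 uM (on this read-out lower numbers stand for slow clearance and higher numbers for fast clearance), compound 3 gives 1.05 mL/min, the second highest of the three numbers. Compound 1, which also carries a 3-chlorophenyl, gives 0.64 mL/min, and the gap between compound 1 and compound 3 is within the scatter. Within the data shown here, the one counted step, a 2.9-fold lower number from compound 2 to compound 3 (0.46 log units; beyond the scatter), swapped the halogen as well as its position, so it does not isolate the position alone.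

Compound 4, `COc1ccc(S(=O)(=O)c2cnc3c(F)cccc3c2-c2cccc(Cl)c2)cc1`, differs from compound 3 by 3-chlorophenyl in place of 4-chlorophenyl on an aromatic carbon. Among the measured compounds shown here, with no step that tests this move on its own, the expected change a 1.1-fold lower number from compound 3 to compound 4 (0.02 log units; within the scatter) is none beyond the scatter. Compound 4 is therefore estimated at 1 mL/min, in the range 0.45 mL/min to 2.3 mL/min.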

Compound 4, intrinsic clearance in a liver preparation (reported as CLH), per the amount of preparation that the assay uses: 2.75 mL/min
For compound 4 the middle estimate is 2.8-fold (0.44 log units) below the measured one, outside the stated range (above it).
By their numbers in this assay, from the lowest: compounds 1 and 3 (each within the scatter of the next); then compounds 4 and 2 (each within the scatter of the next).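

Within the shared core, the place of the chlorine on the pendant phenyl ring counts in this assay: 3-chlorophenyl in place of 4-chlorophenyl gives a clear rise (a 2.6-fold higher number from compound 3 to compound 4 (0.42 log units; beyond the scatter)). With the halogen at the 3-position of that ring, chloro in place of fluoro changes nothing beyond the scatter (a 1.1-fold lower number from compound 2 to compound 4 (0.04 log units; within the scatter)). The group on the sulfonyl sulfur also counts, as 4-methoxyphenyl in place of 3,5-difluorophenyl gives a larger rise (a 4.3-fold higher number from compound 1 to compound 4 (0.63 log units; beyond the scatter)). Nothing available explains these shifts.

The compounds shown leave open how a trifluoromethyl or a nitrile in place of the chlorine would read.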